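An Amino Group Enters the Core of Compound 1

The compounds below may be only part of what the source reports. "The series", "measured", "known", "first", "only" and "open" are said of these compounds alone.

Compound 1, `CCn1cc(-c2nc3ccccc3[nH]2)c(=O)c2cc(F)c(N3CCNCC3)cc21`, gives > 10000 nM in a functional assay on HepG2 cells (Homo sapiens) for cytotoxicity, read by sulforhodamine B assay, with a stated time of 48 h (a higher number here means a weaker inhibitor, a lower number a stronger inhibitor), a limit of the assay.
Compound 2, `CCn1cc(-c2nc3ccc([N+](=O)[O-])cc3o2)c(=O)c2cc(F)c(N3CCNC(C)C3)c(F)c21`, gives 4500 nM in this assay.
Compound 3, `CCn1cc(-c2nc3ccc([N+](=O)[O-])cc3s2)c(=O)c2cc(F)c(N3CCNC(C)C3)c(F)c21`, gives 3600 nM in this assay.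

Compound 1 stands at the limit of > 10000 nM in this assay, at which 1 of the 3 values shown sits. Its result is a limit, not a number, so where compound 1 truly lies on the scale is not known. Compound 2 and compound 3 give numbers that sit within the usual scatter of each other, and no order between them can be read. Within the data shown here, no two measured compounds differ in a single place, so no measured step exists to lean on.

Compound 4, `CCn1cc(-c2nc3ccc(N)cc3[nH]2)c(=O)c2cc(F)c(N3CCNCC3)cc21`, has not yet been measured in this assay. It differs from compound 1 by amino in place of hydrogen on an aromatic carbon. Because compound 1 gives only > 10000 nM, the expected step in this assay is none beyond the scatter, in no clear direction, and the step expected is a number no higher from compound 1 to compound 4 (the limit leaves the size open). Compound 4 is therefore estimated at 10000 nM, with a range from 3000 nM to 30000 nM.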

Compound 4, half-maximal inhibitory concentration: > 10000 nM
Compound 4 ended at the assay's limit (the forecaster's own chance of this, stated with the estimate: 55%); the middle value lies on the limit itself.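

No step can be read from compound 1 to compound 4 in this assay, since each compound ends at a limit of the assay and not at a number: the limit of > 10000 nM in this assay, at which 2 of the 4 values shown sit.

The compounds shown leave open whether amino in place of hydrogen on an aromatic carbon shifts the result at all, and where compound 1 and compound 4 truly lie on the scale.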